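Ring contraction on the propyl-linked arm: compound 2 to compound 4

The source may report more compounds than this note shows. Statements on the series, on what has been measured and on what is new or still open speak of the compounds shown alone.

Compound 1 `C1=C(CCN2CCN(c3cccc4c3OCCO4)CC2)c2ccccc2CCC1`: 380 nM
Compound 2 `c1ccc2c(c1)CC(CCCN1CCN(c3cccc4c3OCCO4)CC1)C2`: 1860 nM
Compound 3 `Fc1cccc2c1CC2CN1CCN(c2cccc3c2OCCO3)CC1`: 316 nM

In an assay on isolated protein for binding affinity to 5-hydroxytryptamine receptor 1B (Rattus norvegicus) (on this read-out higher numbers stand for weaker inhibition and lower numbers for stronger inhibition), compound 2 gives the highest of the three numbers; compound 1 sits lower by a margin beyond the scatter, and compound 3 lies lower still, also beyond the scatter. Compound 4 `c1ccc2c(c1)CC2CCCN1CCN(c2cccc3c2OCCO3)CC1` has not been measured. It differs from compound 2 in one place: a group of 8 heavy atoms (8 carbon; one four-membered non-aromatic ring of carbon only, one six-membered aromatic ring of carbon only) in place of a group of 9 heavy atoms (9 carbon; one five-membered non-aromatic ring of carbon only, one six-membered aromatic ring of carbon only), on a saturated chain carbon, three bonds along the chain from an amine nitrogen in a ring. Among the measured compounds shown here, no measured pair shows this exact change, so its effect is unknown. With the rest of the molecule kept, the step from compound 2 to compound 4 is expected to be small, estimated as a 1.4-fold lower number from compound 2 to compound 4 (0.16 log units; within the scatter), most likely within the scatter. In this assay compound 4 is expected to give 1300 nM, within the range 450 nM to 3800 nM.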

Compound 4, inhibition constant: 646 nM
Compound 4: middle estimate off by 2.0-fold (0.30 log units), on the high side, within the range that was stated.
By their numbers in this assay, from the lowest: compounds 3, 1 and 4 (each within the scatter of the next, the first and the last beyond it); then compound 2.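

In this assay, putting the four-membered carbon ring group in place of 2,3-dihydro-1H-inden-2-yl, on a saturated chain carbon, three bonds along the chain from an amine nitrogen in a ring, gives a 2.9-fold lower number from compound 2 to compound 4 (0.46 log units; beyond the scatter). Among the compounds shown here, this shows that the number at this position responds to the size of the non-aromatic carbon ring, which the earlier compounds could not show, as no two of them differed in one place. Nothing available accounts for this step. Going by these compounds, how a six-membered non-aromatic carbon ring would read at this position remains open, as does the effect of a fluorine on the aromatic ring or a shorter chain.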